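The compounds below may be only part of what the source reports. "The series", "measured", "known", "first", "only" and "open" are said of these compounds alone.

For the measured compounds named here, compound 3 `Cc1c(C(=O)N=C(N)N)cc(S(C)(=O)=O)c(Cl)c1C` stands at the upper end of the three numbers measured so far in a functional assay for inhibition of sodium/hydrogen exchanger (Oryctolagus cuniculus) (on this read-out higher numbers stand for weaker inhibition and lower numbers for stronger inhibition), where compound 3 gives 58 nM. In this assay compound 1 `Cc1cc(Cl)c(S(C)(=O)=O)cc1C(=O)N=C(N)N` gives 25 nM and compound 2 `Cc1c(C(=O)N=C(N)N)cc(S(C)(=O)=O)c(Cl)c1Cl` gives 29 nM. The steps among them were small: a 1.2-fold higher number from compound 1 to compound 2 (0.06 log units; within the scatter), a 2.3-fold higher number from compound 1 to compound 3 (0.37 log units; beyond the scatter) and a 2.0-fold higher number from compound 2 to compound 3 (0.30 log units; within the scatter). Compound 4 `Cc1c(C(=O)N=C(N)N)cc(S(C)(=O)=O)c(Cl)c1[N+](=O)[O-]` differs from compound 3 by nitro in place of methyl on an aromatic carbon. Going by the values given here, all three measured steps concern exchanges at this same position, and none moved the number by much, but no compound with a nitro group there has been measured. The expected step in this assay is a 1.3-fold lower number from compound 3 to compound 4 (0.11 log units; within the scatter). Compound 4 is therefore estimated at 45 nM, within a range of 15 nM to 140 nM.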

Compound 4, half-maximal inhibitory concentration: 44 nM
The estimate for compound 4 lay 1.0-fold (0.01 log units) above the measured number; the range from low to high includes it.
By their numbers in this assay, from the lowest: compounds 1, 2, 4 and 3 (each within the scatter of the next, the first and the last beyond it).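

In this assay, nitro brings more heavy atoms than methyl and two hydrogen-bond acceptors to this position, yet each of its steps stays within the scatter: a 1.3-fold lower number from compound 3 to compound 4 (0.12 log units; within the scatter), a 1.5-fold higher number from compound 2 to compound 4 (0.18 log units; within the scatter) and a 1.8-fold higher number from compound 1 to compound 4 (0.25 log units; within the scatter). Methyl in place of hydrogen went beyond the scatter, though only modestly, whereas nitro in place of hydrogen does not. The position thus tolerates a larger group with hydrogen-bond acceptors without a clear loss in this assay. Going by these compounds, whether an amine or a carboxylic acid here would stay as close remains open. No available evidence bears on why the numbers stay so close.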